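This account rests on a few compounds, and the source may have more. Where it says the series, first, only, none or still open, it means among the compounds named here.

Measured in a functional assay on CCRF-CEM cells (Homo sapiens) for inhibition, read by cell counting, with a stated time of 3 days; a lower number here means a stronger inhibitor, a higher number a weaker inhibitor:
Compound 1 `C=C(Br)C(=O)Nc1cccc(-c2cn3nc(Cc4ccccc4)sc3n2)c1` gives 4200 nM.
Compound 2 `Nc1cccc(-c2cn3nc(Cc4ccccc4)sc3n2)c1` gives 37000 nM.

For the measured compounds named here, compound 1 stands lowest of these two numbers, and the one measured step, an 8.8-fold higher number from compound 1 to compound 2 (0.94 log units; beyond the scatter), concerns the group on the ring nitrogen, not the part changed here. Compound 3 `C=C(Br)C(=O)Nc1cccc(-c2cn3nc(CCc4ccccc4)sc3n2)c1` differs from compound 1 by benzyl in place of phenyl on a saturated chain carbon bound to an aromatic carbon. Going by the values given here, no measured step touches this part of the shared core, so no step beyond the scatter is expected, which means no change at the digits printed from compound 1 to compound 3 (within the scatter). Compound 3 is therefore estimated at 4200 nM, with a range from 1500 nM to 12000 nM.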

Compound 3, half-maximal inhibitory concentration: 4200 nM
Beside the measured number, compound 3's estimate shows no gap at the digits printed; measured number inside the range.
By their numbers in this assay, from the lowest: compounds 1 and 3 (each within the scatter of the next); then compound 2.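

Lengthening benzyl to phenethyl on the shared core gives, in this assay, no change at the digits printed from compound 1 to compound 3 (within the scatter). For the compounds shown here, this is the first look at this side of the molecule: the number holds through this one extension, whereas the earlier step concerned only the group on the ring nitrogen. Nothing measured here offers a reason for this.

Going by these compounds, whether a longer chain such as phenylpropyl, or an amine or carboxylic acid on this chain, would keep the number remains open. So does whether the same change would read alike on compound 2, which lacks the (1-bromoethenyl)carbonyl group.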